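From 3-nitrophenyl to 4-methylphenyl on the shared core

The compounds below may be only part of what the source reports. "The series", "measured", "known", "first", "only" and "open" are said of these compounds alone.

Measured in a functional assay on PC-3 cells (Homo sapiens) for cytotoxicity, read by sulforhodamine B assay, with a stated time of 48 h; a higher number here means a weaker inhibitor, a lower number a stronger inhibitor:
- compound 1 `C[C@H]1CC[C@@H]2[C@@H](OC(=O)[C@]23CC(c2ccccc2Br)=NO3)[C@]2(C)C(=O)C=C[C@@]12O`: 51000 nM
- compound 2 `C[C@H]1CC[C@@H]2[C@@H](OC(=O)[C@]23CC(c2ccc(N(C)C)cc2)=NO3)[C@]2(C)C(=O)C=C[C@@]12O`: 6300 nM
- compound 3 `C[C@H]1CC[C@@H]2[C@@H](OC(=O)[C@]23CC(c2cccc([N+](=O)[O-])c2)=NO3)[C@]2(C)C(=O)C=C[C@@]12O`: 55000 nM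

Compound 3 cannot be told apart from one of its two neighbours, with a 1.1-fold higher number from compound 1 to compound 3 (0.03 log units; within the scatter). It stands clearly on the high side of the remaining one, with an 8.7-fold higher number from compound 2 to compound 3 (0.94 log units; beyond the scatter). The unmeasured compound 4 `Cc1ccc(C2=NO[C@]3(C2)C(=O)O[C@@H]2[C@H]3CC[C@H](C)[C@]3(O)C=CC(=O)[C@@]23C)cc1` keeps the shared core and changes one group: 4-methylphenyl in place of 3-nitrophenyl on a carbon with a double bond to nitrogen.

Among the measured compounds shown here, three measured steps bear on this change, all at the same place. Exchanging 2-bromophenyl for 3-nitrophenyl moved nothing beyond the scatter. The one drop in the series is an 8.1-fold lower number from compound 1 to compound 2 (0.91 log units; beyond the scatter), where 4-(dimethylamino)phenyl enters. The entering 4-methylphenyl shares only its numbering with that group, so with three compounds a small step towards a lower number in this assay is expected, smaller than that drop.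

The estimated change is a 2.5-fold lower number from compound 3 to compound 4 (0.40 log units; beyond the scatter). For compound 4 the expected value is 22000 nM, with an estimated range from 6000 nM to 70000 nM.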

Compound 4, half-maximal inhibitory concentration: 14000 nM
The estimate for compound 4 lay 1.6-fold (0.20 log units) above the measured number, and the stated range covers the measured number.
By their numbers in this assay, from the lowest: compound 2; then compound 4; then compounds 1 and 3 (each within the scatter of the next).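

Among the compounds shown here, compound 4 shows that 4-(dimethylamino)phenyl is not the only group at this position to bring the number down beyond the scatter in this assay: 4-methylphenyl does so as well, with (a 3.9-fold lower number from compound 3 to compound 4 (0.59 log units; beyond the scatter)) and (a 3.6-fold lower number from compound 1 to compound 4 (0.56 log units; beyond the scatter)). Methyl in place of dimethylamino on the aromatic carbon gives part of that gain back (a 2.2-fold higher number from compound 2 to compound 4 (0.35 log units; beyond the scatter)), so among these compounds the two groups named with a 4 stand lower than 2-bromophenyl and 3-nitrophenyl, and no compound shown goes against this. Nothing available gives a reason for these steps.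

The substituent and its place on the phenyl ring change together across these compounds, so the steps do not separate the two. On these data alone, how a 4-methoxyphenyl or a phenyl carrying a carboxylic acid would compare with compound 4 remains open.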